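Trimming the Phenethyl Chain of Compound 1

The compounds below may be only part of what the source reports. "The series", "measured", "known", "first", "only" and "open" are said of these compounds alone.

Compound 1, `O=C(Nc1nn[nH]n1)c1cccc(CCc2ccccc2)n1`: 45%
Compound 2, `Cc1cc([N+](=O)[O-])cc(C(=O)Nc2nn[nH]n2)n1`: 6%
Compound 3, `COc1cc(C)nc(C(=O)Nc2nn[nH]n2)c1`: 20%

Three measured compounds share the core of compound 1 and differ only in what sits on it. In a functional assay on the whole organism for inhibition, with Rattus norvegicus as the target, at a dose of 10 mg/kg by the oral route (on this read-out higher numbers stand for a stronger effect at the one dose given and lower numbers for a weaker effect), compound 1 gives 45% and stands highest of the three, beyond the scatter from both others. Compound 3 gives 20% in this assay. Compound 2 gives 6% in this assay. Among the compounds with values here, the single step between measured compounds, a number 14 percentage points higher from compound 2 to compound 3 (beyond the scatter), concerns a substituent on an aromatic carbon and says nothing about the chain.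

Compound 4, `CCCCc1cccc(C(=O)Nc2nn[nH]n2)n1`, differs from compound 1 by ethyl in place of phenyl on a saturated chain carbon, two bonds along the chain from an aromatic carbon. Within the data shown here, no measured pair shows ethyl in place of phenyl on a saturated chain carbon, so nothing here sets the size of this step, and the data leave its direction open. With the two-carbon chain of compound 1 intact and only the ring removed, a modest loss is expected, possibly still within the scatter. Compound 4 is estimated at 32% in this assay, between 12% and 50%, an expected step of a number 13 percentage points lower from compound 1 to compound 4 (beyond the scatter).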

Compound 4, a percentage reported as inhibition, in the whole organism at one dose (the size of the read-out at that dose, not a potency): 18%
For compound 4 the middle estimate is 14 percentage points above the measured one; measured number inside the range.
By their numbers in this assay, from the lowest: compound 2; then compounds 4 and 3 (each within the scatter of the next); then compound 1.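

In this assay, ethyl in place of phenyl on a saturated chain carbon, two bonds along the chain from an aromatic carbon, gives a number 27 percentage points lower from compound 1 to compound 4 (beyond the scatter), the only step shown that touches the chain rather than a substituent on an aromatic carbon. It shows that this position is not indifferent to the change: the read-out of compound 1 is not kept when the phenyl gives way to ethyl on an otherwise unchanged core. Nothing measured here accounts for the size of this loss.

The compounds shown do not tell whether an aromatic ring is needed at the chain end, or whether a saturated ring such as cyclohexyl would serve in place of the phenyl. They also leave open how a longer chain ending in phenyl, or a phenyl carrying a methoxy group or a chlorine, would compare with compound 1.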